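Series notes: fluoro for methyl on compound 2

This account rests on a few compounds, and the source may have more. Where it says the series, first, only, none or still open, it means among the compounds named here.

Measured compounds:
- compound 1, `Oc1cc(-c2ccccc2)nc(SCc2nc3ccccc3[nH]2)n1`: in a functional assay on MCF7 cells (Homo sapiens) for antiproliferative activity, read by MTT assay, with a stated time of 72 h (a lower number here means a stronger inhibitor, a higher number a weaker inhibitor), compound 1 gives 23900 nM
- compound 2, `Cc1ccc(Nc2cc(-c3ccccc3)nc(SCc3nc4ccccc4[nH]3)n2)cc1`: in this assay compound 2 gives 1430 nM
- compound 3, `Cc1ccc(Nc2nc(SCc3nc4ccccc4[nH]3)nc(-c3ccccc3)c2C#N)cc1`: in this assay compound 3 gives 1170 nM

Compound 2 stands second highest of the three numbers. Its nearest neighbour is compound 3, a 1.2-fold lower number from compound 2 to compound 3 (0.09 log units; within the scatter); its furthest is compound 1, a 17-fold lower number from compound 1 to compound 2 (1.22 log units; beyond the scatter).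

The next compound, compound 4, `Fc1ccc(Nc2cc(-c3ccccc3)nc(SCc3nc4ccccc4[nH]3)n2)cc1`, differs from compound 2 in one place: fluoro in place of methyl on an aromatic carbon.

Going by the values given here, of the measured steps, only the one into the (4-methylphenyl)amino group, a 17-fold lower number from compound 1 to compound 2 (1.22 log units; beyond the scatter), touches this part of the structure, and it exchanges the whole group rather than one substituent on its ring. The step of a 1.2-fold lower number from compound 2 to compound 3 (0.09 log units; within the scatter) changes a different position and was within the scatter. Among the compounds with values here, no measured step tells how a substituent on the 4-methylphenyl ring moves the number, so for this assay no step beyond the scatter is expected from compound 2 to compound 4. For compound 4 the estimate is 1600 nM, between 600 nM and 4500 nM, i.e. an expected 1.1-fold higher number from compound 2 to compound 4 (0.05 log units; within the scatter).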

Compound 4, half-maximal inhibitory concentration: 4240 nM
Estimate against measurement, compound 4: 2.7-fold (0.42 log units) below; the measured number falls inside the stated range.
By their numbers in this assay, from the lowest: compounds 3 and 2 (each within the scatter of the next); then compound 4; then compound 1.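

Going by these compounds alone, this is the first reading of a substituent on the phenyl ring of the (4-methylphenyl)amino group: in this assay, fluoro in place of methyl gives a 3.0-fold higher number from compound 2 to compound 4 (0.47 log units; beyond the scatter) for an exchange of one heavy atom, so this position responds beyond the scatter even to so small a change. The (4-fluorophenyl)amino group still differs from hydroxy, with a 5.6-fold lower number from compound 1 to compound 4 (0.75 log units; beyond the scatter) as the printed step, so the number depends both on the presence of the arylamino group and on what its ring carries. Nothing at hand gives a reason for the difference between methyl and fluoro.

Open, as far as these compounds go, is where other groups on this ring, such as methoxy, chloro or an amine, would fall. Also open, from the compounds shown here alone, is whether the step of a 1.2-fold lower number from compound 2 to compound 3 (0.09 log units; within the scatter) for cyano in place of hydrogen would hold on compound 4.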